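This account rests on a few compounds, and the source may have more. Where it says the series, first, only, none or still open, it means among the compounds named here.

Measured compounds:
compound 1, `CC(C)n1ncc2c(C(=O)NCc3ccccc3)cccc21`: > 40000 nM
compound 2, `CC(C)n1ncc2c(C(=O)NCc3cn(-c4cccc(F)c4)nn3)cccc21`: > 40000 nM

Both numbers come from a functional assay on HepG2 cells (Homo sapiens) for inhibition, read by MTT assay, with a stated time of 72 h (on this read-out lower numbers stand for stronger inhibition and higher numbers for weaker inhibition), and neither is a measured concentration. For compound 1 the assay reports only the limit > 40000 nM. For compound 2 it likewise reports only the limit > 40000 nM. Among the compounds with values here, compound 2 therefore cannot be placed on a scale of potency; what is known is the limit of > 40000 nM in this assay, at which 2 of the 2 values shown sit, and the one other value shown sits there as well. Within the data shown here, no step between two measured compounds is available, so nothing is known from these data about how much any structural change shifts this assay.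

Compound 3, `COc1ccc(-n2cc(CNC(=O)c3cccc4c3cnn4C(C)C)nn2)cc1`, has not been measured yet. It differs from compound 2 in one place: 4-methoxyphenyl in place of 3-fluorophenyl on an aromatic nitrogen. Because the limit of > 40000 nM in this assay, at which 2 of the 2 values shown sit, holds every value shown, the step from compound 2 to compound 3 in this assay is expected to be a step that the limit leaves unreadable from compound 2 to compound 3, with no shift beyond the scatter discernible. Compound 3 is accordingly estimated at 50000 nM, in a range from 15000 nM to 200000 nM, and most likely to be reported again only as a limit.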

Compound 3, half-maximal inhibitory concentration: > 40000 nM
Compound 3: a limit, no number; the forecaster's own chance of this, stated with the estimate: 80%; the middle value is on the limit's open side.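

In this assay compound 3 gives only a limit, > 40000 nM. Within the data shown here, compound 2 is also reported only as a limit, so no step between compound 2 and compound 3 can be read: the limit of > 40000 nM in this assay, at which 3 of the 3 values shown sit. The compounds shown leave open whether any structural change would yield a measured number rather than a limit in this assay.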